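A few compounds are considered here, and "the series" means these few. Any claim that something is new, unique, unknown or untested is made for them only; others in the source may bear on it.

Going by the values given here, compound 1 `Cc1cc(C)cc(-n2cc(COC(=O)c3cc4ccccc4[nH]3)nn2)c1` is one of only two compounds that carry a number in a functional assay on HeLa cells (Homo sapiens) for cytotoxicity, read by MTT assay, with a stated time of 48 h; a lower number here means a stronger inhibitor, a higher number a weaker inhibitor. In this assay compound 1 gives 30200 nM, the lower of the two values recorded. The other measured compound is compound 2 `CCCCc1ccc(-n2cc(COC(=O)c3cc4ccccc4n3Cc3cn(-c4ccc(CCCC)cc4)nn3)nn2)cc1`; in this assay compound 2 gives 42800 nM, and this value lies within the usual scatter of the value of compound 1, so the two cannot be told apart on these numbers, and neither can be called the stronger inhibitor.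

Compound 3 `O=C(OCc1cn(-c2ccccc2Br)nn1)c1cc2ccccc2[nH]1` has not yet been measured. It differs from compound 1 in one place: 2-bromophenyl in place of 3,5-dimethylphenyl on an aromatic nitrogen. Among the compounds with values here, no measured pair in this set differs by a swap of this kind, so the two known numbers give no direct guide to what the change will do.

Within the data shown here, with only two measured values, close to each other, the expected step from compound 1 to compound 3 is a 1.0-fold lower number from compound 1 to compound 3 (0.00 log units; within the scatter), which is no larger than the scatter and could fall in either direction. Compound 3 is therefore estimated at 30000 nM, with a range from 10000 nM to 90000 nM.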

Compound 3, half-maximal inhibitory concentration: 17300 nM
Estimate against measurement, compound 3: 1.7-fold (0.24 log units) above; low and high end bracket the measured number.
By their numbers in this assay, from the lowest: compounds 3, 1 and 2 (each within the scatter of the next, the first and the last beyond it).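

In this assay, putting 2-bromophenyl in place of 3,5-dimethylphenyl on the aromatic nitrogen gives a 1.7-fold lower number from compound 1 to compound 3 (0.24 log units; within the scatter), so the first step seen at this position does not separate the two compounds. The position therefore carries either of these two groups with no measurable difference in this assay, even though the two phenyl rings bear different substituents in different places; both groups are a single six-membered aromatic ring of carbon only, with no hydrogen-bond donors or acceptors and no net charge. No measurement on hand bears on what might lie behind this result.

This single step leaves open whether any group on this phenyl ring can move the number beyond the scatter, since a carboxylic acid, an amine or a longer chain in that place would test a far more different kind of group than bromine or methyl. It also cannot say whether the bromine and the two methyl groups each have no effect or whether separate effects happen to cancel, which a plain unsubstituted phenyl would help to settle.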